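The compounds below may be only part of what the source reports. "The series", "measured", "known", "first", "only" and "open" are said of these compounds alone.

Compound 1, `COc1cc(C(=O)c2sc(-c3cccs3)cc2N)cc(OC)c1OC`, gives 9.8 nM in a functional assay on L1210 cells (Mus musculus) for antiproliferative activity; on this read-out lower numbers stand for stronger inhibition and higher numbers for weaker inhibition.
Compound 2, `COc1cc(C(=O)c2sc(-c3ccc(Cl)cc3)cc2N)cc(OC)c1OC`, gives 93 nM in this assay.

For the measured compounds named here, of the two numbers, compound 2 stands at the higher one; the only measured step, a 9.5-fold higher number from compound 1 to compound 2 (0.98 log units; beyond the scatter), separates it from compound 1. Compound 3, `COc1cc(C(=O)c2sc(-c3ccc(C(F)(F)F)cc3)cc2N)cc(OC)c1OC`, differs from compound 2 by trifluoromethyl in place of chloro on an aromatic carbon. Going by the values given here, no measured step bears on this exchange, since the single step known here alters a different group. Without guidance from the data, the step of a 1.3-fold higher number from compound 2 to compound 3 (0.11 log units; within the scatter) is expected to stay within the scatter, in no clear direction. Compound 3 is therefore estimated at 120 nM, with a range from 40 nM to 400 nM.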

Compound 3, half-maximal inhibitory concentration: 370 nM
Beside the measured number, compound 3's estimate is 3.1-fold (0.49 log units) below it; low and high end bracket the measured number.
By their numbers in this assay, from the lowest: compound 1; then compound 2; then compound 3.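

Within the 4-substituted phenyl series, the group on the ring matters in this assay: trifluoromethyl in place of chloro gives a 4.0-fold higher number from compound 2 to compound 3 (0.60 log units; beyond the scatter), so the number moves with this substituent and not only with the loss of thiophen-2-yl. Measured against thiophen-2-yl, the gap widens to a 38-fold higher number from compound 1 to compound 3 (1.58 log units; beyond the scatter), and compound 1 keeps the lowest number of the three. Nothing at hand accounts for the change. Going by these compounds, whether fluoro, methoxy or an amine in the same place would bring the number closer to that of compound 1 remains open.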